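Reversed amide with an oxane ring on a pyrazole core

The compounds below may be only part of what the source reports. "The series", "measured", "known", "first", "only" and "open" are said of these compounds alone.

Measured compounds:
compound 1 `Cc1cc(C(=O)O)nn1C(C)c1cc(Cl)ccc1OCc1ccccc1` gives 10 nM in an assay on CHO-K1 cells for displacement of a labelled ligand from prostaglandin E2 receptor EP1 subtype (Homo sapiens); a lower number here means a stronger inhibitor, a higher number a weaker inhibitor
compound 2 `Cc1cc(C(=O)Nc2c(F)cccc2F)nn1Cc1cc(Cl)ccc1OCc1ccccc1` gives 10 nM in this assay
compound 3 `Cc1cc(C(=O)NN2CCCCC2)nn1Cc1cc(Cl)ccc1OCC(C)C` gives 200 nM in this assay

Compound 2 sits level with compound 1 at the digits shown, and the two of them share the lowest numbers of the three. Compound 3 stands furthest away, with a number that lies well beyond the scatter above that of compound 2.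

Compound 4 `Cc1cc(NC(=O)C2CCOCC2)nn1Cc1cc(Cl)ccc1OCc1ccccc1` has not yet been measured. It differs from compound 2 in one place: ((oxan-4-yl)carbonyl)amino in place of (2,6-difluorophenyl)carbamoyl on an aromatic carbon.

Going by the values given here, the step from compound 2 to compound 4 is expected to raise the number moderately, by about a 5.0-fold higher number from compound 2 to compound 4 (0.70 log units; beyond the scatter), since no measured pair shows this kind of change on its own. For compound 4 the estimated value in this assay is 50 nM, within a range from 10 nM to 300 nM.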

Compound 4, half-maximal inhibitory concentration: 63.1 nM
Beside the measured number, compound 4's estimate is 1.3-fold (0.10 log units) below it, within the range that was stated.
By their numbers in this assay, from the lowest: compounds 1 and 2 (each within the scatter of the next); then compound 4; then compound 3.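

In this assay, replacing (2,6-difluorophenyl)carbamoyl with ((oxan-4-yl)carbonyl)amino on this aromatic carbon gives a 6.3-fold higher number from compound 2 to compound 4 (0.80 log units; beyond the scatter), so the position accepts a turned-around amide with a non-aromatic ring, though at a measurable cost. Compound 4 still lies on the stronger side of compound 3, but those two differ in more than one place, so that comparison says little. No measurement shown here explains the step.

The amide direction and the ring change together, so the compounds shown cannot separate their contributions. As far as these compounds go, a turned-around amide carrying the 2,6-difluorophenyl ring, or a cyclohexane ring in place of the oxane ring, remains open.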